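A few compounds are considered here, and "the series" means these few. Any claim that something is new, unique, unknown or untested is made for them only; others in the source may bear on it.

Compound 1, `CCCCCCCCCCCCCCCCc1c(C)c(N(C)C)nc(C)c1O`, gives 96% in a functional assay on cells (Lymphocyte), read by a luciferase reporter and ATP content, with a stated time of 48 h, tested at 5 uM; a lower number here means a stronger effect, a higher number a weaker effect of the compound at the concentration tested.
Compound 2, `CCCCCCCCCCc1c(C)c(N(C)C)nc(C)c1O`, gives 87% in this assay.
Compound 3, `CCCCCCCCCCCCCCCCc1c(C)c(N2CCC2)nc(C)c1O`, gives 98% in this assay.

Compound 2 stands lowest of the three numbers: its nearest neighbour is compound 1, which lies higher but within the scatter, and its furthest is compound 3, which lies higher beyond the scatter. Compound 4, `CCCCCCCCCCCCCCCCCCCc1c(C)c(N(C)C)nc(C)c1O`, has not yet been measured in this assay. It differs from compound 2 by nonyl in place of hydrogen on a saturated chain carbon, ten or more bonds along the chain from an aromatic carbon. Going by the values given here, the one measured step that bears on this change is a number 9 percentage points lower from compound 1 to compound 2 (within the scatter), which ran the other way, from the longer chain to the shorter one, and stayed within the scatter. The other step, a number 2 percentage points higher from compound 1 to compound 3 (within the scatter), touches a different part of the shared core and says nothing about chain length. The change to compound 4 lengthens the chain by more than the earlier step shortened it, so a step back upward in this assay is expected, of a size around the scatter, a number 8 percentage points higher from compound 2 to compound 4 (within the scatter). Compound 4 is therefore estimated at 95%, with a range from 84% to 104%.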

Compound 4, a percentage reported as activity, at one concentration (the size of the read-out at that concentration, not a potency): 106%
Compound 4: the middle estimate sits 11 percentage points below what was measured; the whole stated range lies below it.
By their numbers in this assay, from the lowest: compounds 2, 1, 3 and 4 (each within the scatter of the next, the first and the last beyond it).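

In this assay the chain position now shows a step beyond the scatter: with nonyl in place of hydrogen on a saturated chain carbon, ten or more bonds along the chain from an aromatic carbon, the result is a number 19 percentage points higher from compound 2 to compound 4 (beyond the scatter). The smaller change at that position, propyl in place of hydrogen, gives a number 10 percentage points higher from compound 1 to compound 4 (within the scatter), so only the wider change in chain length separates two compounds beyond the scatter. Nothing measured here accounts for this step.

From the compounds shown here alone, compound 2, compound 1 and compound 4 carry only unbranched saturated chains, so it stays open whether a chain carrying an amine or a carboxylic acid would fit the same trend. Going by these compounds alone, also open is how azetidin-1-yl, seen only with the chain of compound 3, behaves with a decyl or longer chain.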